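Methoxy position on the amide aryl of compound 2

The source may report more compounds than this note shows. Statements on the series, on what has been measured and on what is new or still open speak of the compounds shown alone.

Compound 1 `Cc1cc(NCCN(C)C)nc2ccc(NC(=O)c3ccc(Cl)c(Cl)c3)cc12` gives 6670 nM in a functional assay on SK-BR-3 cells (Homo sapiens) for antiproliferative activity, read by MTT assay, with a stated time of 72 h; on this read-out lower numbers stand for stronger inhibition and higher numbers for weaker inhibition; compound 3 `Cc1cc(N2CCCCC2)nc2ccc(NC(=O)c3ccc(Cl)c(Cl)c3)cc12` gives 42500 nM; compound 2 `CCN1CCN(c2cc(C)c3cc(NC(=O)c4ccc(OC)cc4)ccc3n2)CC1` gives 9000 nM. Compound 2 thus stands second highest of the three numbers, with compound 1 within the scatter of it and compound 3 beyond. For the measured compounds named here, the one single-site step measured so far, a 6.4-fold higher number from compound 1 to compound 3 (0.80 log units; beyond the scatter), concerns the amine on the shared core and leaves the amide aryl untouched. Compound 4 `CCN1CCN(c2cc(C)c3cc(NC(=O)c4ccccc4OC)ccc3n2)CC1` differs from compound 2 by 2-methoxyphenyl in place of 4-methoxyphenyl on a carbonyl carbon. Going by the values given here, no measured step bears on this change, so no step beyond the scatter is expected in this assay, and the estimate rests on compound 2 with a widened range. For compound 4 the expected value is 9000 nM, with a range of 3000 nM to 27000 nM. The expected step is no change at the digits printed from compound 2 to compound 4 (within the scatter).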

Compound 4, half-maximal inhibitory concentration: 15700 nM
Compound 4: the middle estimate sits 1.7-fold (0.24 log units) below what was measured; low and high end bracket the measured number.
By their numbers in this assay, from the lowest: compounds 1, 2 and 4 (each within the scatter of the next, the first and the last beyond it); then compound 3.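

In this assay, for the compounds shown here, the first step at the amide aryl reads a 1.7-fold higher number from compound 2 to compound 4 (0.24 log units; within the scatter), so moving the methoxy from 4-methoxyphenyl to 2-methoxyphenyl on a carbonyl carbon stays inside the scatter. Going by these compounds alone, the earlier step changed only the amine on the shared core, so this is the first reading on the aryl side, and for this one pair the methoxy position makes no clear difference. No measured evidence bears on this result.

Open, on these data alone, is whether a hydroxy or an amino group in place of the methoxy would give a step beyond the scatter. Also open, as far as these compounds go, is whether the same methoxy move would read alike with the amines of compound 1 and compound 3.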